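A few compounds are considered here, and "the series" means these few. Any claim that something is new, unique, unknown or untested is made for them only; others in the source may bear on it.

In an ADME assay on THP-1 cells (Homo sapiens) for cytotoxicity, read by MTT assay (a lower number here means that less compound is tolerated, a higher number that more compound is tolerated), compound 1 (`Cc1nc(-c2cccnc2)sc1-c1nnc(Cc2ccccc2)o1`) gives > 100 ug/mL as a limit of the assay, not a number. Compound 2 (`Cc1nc(-c2cccnc2)sc1-c1nnc(-c2ccccc2Cl)o1`) gives > 100 ug/mL as a limit too. Compound 3 (`Cc1cccc(-c2nnc(-c3sc(-c4cccnc4)nc3C)o2)c1`) likewise gives > 100 ug/mL as a limit. Compound 3 therefore stands with the other two (the limit of > 100 ug/mL in this assay, at which 3 of the 3 values shown sit). Compound 4 (`Cc1nc(-c2cccnc2)sc1-c1nnc(-c2cccnc2)o1`) has pyridin-3-yl in place of 3-methylphenyl on an aromatic carbon. The measured changes that bear on this one are (a step that the two limits leave unreadable from compound 1 to compound 3) and (a step that the two limits leave unreadable from compound 2 to compound 3), and neither has a readable size. They support no expected step beyond the scatter in this assay and no direction. For compound 4 the estimated value is 130 ug/mL with an expected range from 50 ug/mL to 300 ug/mL in this assay again. The expected step is small (a step that the limit leaves unreadable from compound 3 to compound 4).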

Compound 4, half-maximal cytotoxic concentration: > 100 ug/mL
Compound 4: only a limit was reported (the forecaster's own chance of this, stated with the estimate: 80%); the middle value lies beyond the limit too.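

In this assay compound 4 gives > 100 ug/mL, a limit of the assay, so its steps from compound 1, compound 2 and compound 3 cannot be read: the limit of > 100 ug/mL in this assay, at which 4 of the 4 values shown sit. On these data alone, whether these four compounds differ at all in the concentration tolerated, and by how much, stays open.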